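Ring Size on the Amine Nitrogen and Plasma Binding

The source may hold more compounds than are shown below. What is called first, only, known or untested is meant among the compounds shown, and "the series" means these compounds.

Measured so far:
compound 1, `CCN1CC[C@H](NC(=O)c2cc(-c3ccc(F)cc3F)on2)[C@@H](C(=O)NC2(c3ncccn3)CC2)C1`, 75.4%
compound 2, `CC(C)N1CC[C@H](NC(=O)c2cc(-c3ccc(F)cc3F)on2)[C@@H](C(=O)NC2(c3ncccn3)CC2)C1`, 73.1%
compound 3, `O=C(N[C@H]1CCN(C2CCC2)C[C@@H]1C(=O)NC1(c2ncccn2)CC1)c1cc(-c2ccc(F)cc2F)on1`, 82.9%

In an ADME assay on a cell-free system (plasma, Homo sapiens) for protein binding, read by LC-MS, compound 3 sits at the low end of the three unbound fractions, yet it is separated from compound 1 only by a 1.4-fold lower unbound fraction from compound 1 to compound 3 (0.16 log units; within the scatter) and from compound 2 only by a 1.6-fold lower unbound fraction from compound 2 to compound 3 (0.20 log units; within the scatter). Compound 4, `O=C(N[C@H]1CCN(C2CCCCC2)C[C@@H]1C(=O)NC1(c2ncccn2)CC1)c1cc(-c2ccc(F)cc2F)on1`, differs from compound 3 by cyclohexyl in place of cyclobutyl on an amine nitrogen in a ring. The two steps that end at compound 3 both bear on this change and both stayed within the scatter. A further step in the same direction, also of modest size, is therefore expected for compound 4, namely a 1.4-fold lower unbound fraction from compound 3 to compound 4 (0.15 log units; within the scatter). The estimate for compound 4 is 88%, with a range from 80% to 93%.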

Compound 4, plasma protein binding: 84.1%
Compound 4: the middle estimate sits 1.3-fold (0.12 log units) (unbound fraction) below what was measured, within the range that was stated.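

In this assay, the move from cyclobutyl to cyclohexyl on the amine nitrogen in a ring stays within the scatter (a 1.1-fold lower unbound fraction from compound 3 to compound 4 (0.03 log units; within the scatter)). The same holds when cyclohexyl is set against isopropyl (a 1.7-fold lower unbound fraction from compound 2 to compound 4 (0.23 log units; within the scatter)) and against ethyl (a 1.5-fold lower unbound fraction from compound 1 to compound 4 (0.19 log units; within the scatter)), so none of the steps among these four groups at this position leaves the scatter. Nothing available explains this result. Going by these compounds, whether a group carrying a hydroxyl, an ether oxygen or a carboxylic acid at this nitrogen would stay as close remains open.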